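This account rests on a few compounds, and the source may have more. Where it says the series, first, only, none or still open, it means among the compounds named here.

Measured so far:
compound 1 `COc1ccccc1N1C(=O)C(C)SC1c1cccc(C(=O)NCCCCc2ccccc2)c1`: 82%
compound 2 `COc1cccc(OC)c1N1C(=O)CSC1c1cccc(C(=O)NCCCCc2ccccc2)c1`: 80%
compound 3 `CCOc1ccccc1N1C(=O)C(C)SC1c1cccc(C(=O)NCCCCc2ccccc2)c1`: 82%

All three were tested in a functional assay on HOS cells (Homo sapiens) for inhibition, read by CCK-8 assay, with a stated time of 72 h, tested at 1 uM; a higher number here means more inhibition at the concentration tested (going by the name of the read-out), a lower number less inhibition. Compound 2 carries the lowest of the three numbers as written, but its gaps to compound 1 and to compound 3 are both within the scatter, so the three compounds cannot be told apart on this evidence. Among the measured compounds shown here, the one step that is measured is no change at the digits printed from compound 1 to compound 3 (within the scatter), which concerns a different part of the molecule and does not touch the aromatic ring on the ring nitrogen. Compound 1 and compound 2 differ in more than one place, and their values simply sit close together.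

The unmeasured compound 4 `COc1c(F)cccc1N1C(=O)CSC1c1cccc(C(=O)NCCCCc2ccccc2)c1` arises from compound 2 by the change (3-fluoro-2-methoxyphenyl in place of 2,6-dimethoxyphenyl on an amide-type nitrogen in a ring). For the measured compounds named here, no measured step speaks to this kind of exchange, so the expectation rests only on the narrow spread of the three numbers: a step of no change at the digits printed from compound 2 to compound 4 (within the scatter) is expected, nothing beyond the scatter. Compound 4 is therefore estimated at 80%, between 68% and 90%.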

Compound 4, a percentage reported as inhibition, at one concentration (the size of the read-out at that concentration, not a potency): 9%
Compound 4: middle estimate off by 71 percentage points, on the high side, outside the stated range (below it).
By their numbers in this assay, from the lowest: compound 4; then compounds 2, 1 and 3 (each within the scatter of the next).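

In this assay, the aromatic group on the ring nitrogen proves decisive: replacing 2,6-dimethoxyphenyl with 3-fluoro-2-methoxyphenyl gives a number 71 percentage points lower from compound 2 to compound 4 (beyond the scatter) and leaves the rest of the molecule unchanged. The earlier compounds shown here, whose numbers all lie within the scatter of one another, gave no sign of such sensitivity at this position, and this step shows that keeping one methoxy group on the same kind of aromatic ring does not preserve the inhibition. No available evidence offers a reason for this drop.

The step removes one methoxy group and introduces a fluorine at once, and the compounds shown do not separate the contribution of either change. Also open, on these data alone, is how this position responds to other groups on the aromatic ring, such as a chlorine, a hydroxyl or an amine.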